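A few compounds are considered here, and "the series" means these few. Any claim that something is new, unique, unknown or untested is made for them only; others in the source may bear on it.

Working notes on the series. In a functional assay on cells (Cancer cell lines, Homo sapiens) for cytotoxicity, read by sulforhodamine B assay, with a stated time of 48 h (a higher number here means a weaker inhibitor of growth, a lower number a stronger inhibitor of growth), compound 2 `COc1ccc(C2CC(c3ccccc3)=NN2C2=NC(=O)/C(=C3\C(=O)Nc4ccc(Br)cc43)S2)cc1` gives 510 nM. Compound 1 `O=C1N=C(N2N=C(c3ccccc3)CC2c2ccccc2O)S/C1=C1/C(=O)Nc2ccc(Br)cc21` gives 670 nM in this assay, and the two lie within the scatter of one another, so neither stands apart from the other. For the measured compounds named here, the step of a 1.3-fold lower number from compound 1 to compound 2 (0.12 log units; within the scatter) is the only measured change at this aromatic ring of the shared core. Compound 3 `CN(C)c1ccc(C2CC(c3ccccc3)=NN2C2=NC(=O)/C(=C3\C(=O)Nc4ccc(Br)cc43)S2)cc1` is not yet measured; it differs from compound 2 by dimethylamino in place of methoxy on an aromatic carbon. Going by the values given here, no measured step bears directly on the exchange of methoxy for dimethylamino, and the one step at the same ring stayed within the scatter, which gives no ground to expect a shift beyond it here. Compound 3 is therefore expected to give about 500 nM in this assay, within 250 nM to 1000 nM. The step of a 1.0-fold lower number from compound 2 to compound 3 (0.01 log units; within the scatter) is estimated to remain within the scatter.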

Compound 3, concentration for total growth inhibition: 540 nM
Beside the measured number, compound 3's estimate is 1.1-fold (0.03 log units) below it, within the range that was stated.
By their numbers in this assay, from the lowest: compounds 2, 3 and 1 (each within the scatter of the next).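

In this assay, dimethylamino in place of methoxy on an aromatic carbon, para to a large group, gives a 1.1-fold higher number from compound 2 to compound 3 (0.02 log units; within the scatter) and so leaves the number within the scatter. The larger exchange of 2-hydroxyphenyl for 4-(dimethylamino)phenyl on the saturated ring carbon gives a 1.2-fold lower number from compound 1 to compound 3 (0.09 log units; within the scatter) and also stays within the scatter, so the three aryl groups shown at this position cannot be told apart by this read-out. No measurement shown accounts for this result.

From the compounds shown here alone, whether a carboxylic acid, a primary amine or a longer alkoxy chain on this aromatic carbon would move the number beyond the scatter remains open. The compounds shown also leave open how an unsubstituted phenyl at the saturated ring carbon would compare with these three aryl groups.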